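Chain lengthening in sigma-1 binding of hydroxypiperidine flavone ethers

The source may report more compounds than this note shows. Statements on the series, on what has been measured and on what is new or still open speak of the compounds shown alone.

The measured compounds and their values:
compound 1, `O=c1cc(-c2ccccc2)oc2cccc(OCCCN3CCC(O)CC3)c12`, 125 nM
compound 2, `O=c1cc(-c2ccccc2)oc2cccc(OCCCCN3CCC(O)CC3)c12`, 58 nM
compound 3, `COc1ccc(-c2cc(=O)c3cc(OCCCCCN4CCC(O)CC4)ccc3o2)cc1`, 493 nM

In an assay on isolated protein (Cavia porcellus) with Sigma non-opioid intracellular receptor 1 (Homo sapiens) as the target, read by radioligand binding (on this read-out higher numbers stand for weaker inhibition and lower numbers for stronger inhibition), compound 1 gives 125 nM and compound 2 gives 58 nM. The change between them is (4-hydroxypiperidin-1-yl)methyl in place of 4-hydroxypiperidin-1-yl on a saturated chain carbon, three bonds along the chain from an oxygen on an aromatic ring, and it made the step of a 2.2-fold lower number from compound 1 to compound 2 (0.33 log units; beyond the scatter). Compound 3 gives 493 nM in this assay, the highest of the three numbers; its core is not the core of compound 1, and the difference between the two cores is not broken down here.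

Compound 4, `COc1ccc(-c2cc(=O)c3cc(OCCCCCCN4CCC(O)CC4)ccc3o2)cc1`, is not yet measured. It differs from compound 3 by (4-hydroxypiperidin-1-yl)methyl in place of 4-hydroxypiperidin-1-yl on a saturated chain carbon, five bonds along the chain from an oxygen on an aromatic ring. This is the same kind of change as that from compound 1 to compound 2, though not the same: there the place was three bonds along the chain from an oxygen on an aromatic ring, here it is five bonds along the chain. Because the earlier step of a 2.2-fold lower number from compound 1 to compound 2 (0.33 log units; beyond the scatter) was modest and the cores differ, only a modest step of a 1.6-fold lower number from compound 3 to compound 4 (0.22 log units; within the scatter) is expected, and compound 4 is estimated at 300 nM in this assay, between 150 nM and 700 nM.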

Compound 4, half-maximal inhibitory concentration: 254 nM
Estimate against measurement, compound 4: 1.2-fold (0.07 log units) above; low and high end bracket the measured number.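

In this assay, the same change on the core of compound 3 gives a 1.9-fold lower number from compound 3 to compound 4 (0.29 log units; within the scatter), and it cannot be told apart from the earlier step on the core of compound 1: the same change on two cores in this assay, a 2.2-fold lower number (0.33 log units; beyond the scatter) from compound 1 to compound 2 and a 1.9-fold lower number (0.29 log units; within the scatter) from compound 3 to compound 4, 1.1-fold (0.05 log units) apart, within the scatter of two such steps. Read together, the two steps show that this change carried over from one core to the other with a step of like size, although the new step does not clear the scatter on its own. The account rests on a single pair for each core, at different places along the chain, so it does not show that the step would hold at other chain lengths or on a further core, nor does it explain why the two steps agree.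

The compounds shown leave open how the step would run with a longer chain, or with a piperazine or morpholine in place of the 4-hydroxypiperidin-1-yl group. They also leave open how the two cores compare at one and the same chain length.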